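A few compounds are considered here, and "the series" means these few. Any claim that something is new, unique, unknown or untested is made for them only; others in the source may bear on it.

Of the compounds shown here, three have so far been measured in a functional assay on CHO cells for antagonist activity at sphingosine 1-phosphate receptor 2 (Homo sapiens), read by GTPgammaS binding; on this read-out lower numbers stand for stronger inhibition and higher numbers for weaker inhibition. Compound 1 `COc1cc(OC)c(NC(=O)Cn2nc(CC(=O)O)c3ccccc32)cc1Cl` gives 8980 nM. Compound 2 `CCC(C(=O)O)c1nn(Cc2cn3cc(OCC4CC4)c(Cl)cc3n2)c2ccccc2c1=O` gives 43 nM, and compound 3 `O=C(O)Cn1nc(Cn2cc3cc(OCC4CC4)c(Cl)cc3n2)c2ccccc2c1=O` gives 53 nM. Compound 2 has the lowest of the three numbers; its gap to compound 3 lies within the usual scatter of repeated measurements, while compound 1 lies far beyond it. Compound 4 `CC(C(=O)O)c1nn(Cc2cn3cc(OCC4CC4)c(Cl)cc3n2)c2ccccc2c1=O` has not yet been measured. It differs from compound 2 in one place: hydrogen in place of methyl on a saturated chain carbon, two bonds along the chain from an aromatic carbon and a carbonyl carbon. Within the data shown here, no measured pair shows this change directly, so its size is uncertain. Trimming the side chain by one methyl is expected to shift the number only slightly, and the step of a 1.4-fold higher number from compound 2 to compound 4 (0.14 log units; within the scatter) is estimated to stay within the scatter. Compound 4 is therefore expected to give about 60 nM, with a likely range from 25 nM to 150 nM.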

Compound 4, half-maximal inhibitory concentration: 31 nM
Estimate against measurement, compound 4: 1.9-fold (0.29 log units) above; the range from low to high includes it.
By their numbers in this assay, from the lowest: compounds 4, 2 and 3 (each within the scatter of the next); then compound 1.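

In this assay, the change from 1-carboxypropyl to 1-carboxyethyl gives a 1.4-fold lower number from compound 2 to compound 4 (0.14 log units; within the scatter). This first direct comparison at this saturated chain carbon shows that removing the methyl does not move the number beyond the scatter, so the two side chains cannot be told apart on this read-out. Nothing available explains this result. On these data alone, whether a longer chain such as butyl, or a cyclopropyl ring, would be accommodated on this carbon remains open, as does the effect of an amide in place of the carboxylic acid.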